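Swapping Nitro for Fluoro in a Pair of Compounds

The source may hold more compounds than are shown below. What is called first, only, known or untested is meant among the compounds shown, and "the series" means these compounds.

Compound 1 `CC1(C)CC(=O)C2=C(C1)NC(c1ccccc1)=CC2c1ccc([N+](=O)[O-])cc1` was examined in an assay on isolated protein for inhibition of glucose-6-phosphatase catalytic subunit 1 (Homo sapiens), read by inositol phosphate accumulation, with a stated time of 30 min, tested at 100 uM; a lower number here means less inhibition, a higher number more inhibition at the concentration tested (going by the name of the read-out). In this assay compound 1 gives "not active" (no number reported), so no single number places it on the scale; it simply showed nothing measurable at the concentration tested. A second compound, compound 2 `CC1(C)CC(=O)c2c(-c3ccc(Cl)cc3)cc(-c3ccccc3)nc2C1`, shares part of its structure but differs in more than one place. In this assay compound 2 gives 11.3%, a small read-out that lies within the usual scatter of repeated measurements. The two compounds differ in several places. Among the compounds with values here, no single step between them is computed.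

Compound 3 `CC1(C)CC(=O)C2=C(C1)NC(c1ccccc1)=CC2c1ccc(F)cc1` differs from compound 1 in one place: fluoro in place of nitro on an aromatic carbon. Neither measured compound shows inhibition beyond the scatter, and nothing in their numbers suggests that this exchange of one small group would raise the read-out. The expected step for this change in this assay is therefore none beyond the scatter, in no particular direction. Compound 3 is expected to give about 5% in this assay, within a range from -10% to 20%. It may equally be reported as not active, as compound 1 was.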

Compound 3, a percentage reported as inhibition, at one concentration (the size of the read-out at that concentration, not a potency): 7.38%
Compound 3: the middle estimate sits 2.4 percentage points below what was measured; measured number inside the range.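

In this assay compound 1 gives "not active" (no number reported) and thus has no number from which a step to compound 3 could be read. No measurement shown here offers an explanation for the result. The compounds shown leave open whether fluoro in place of nitro changes the inhibition at all, and in which direction.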